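From Methylphenyl to Formylthiophene on the Shared Amine

A few compounds are considered here, and "the series" means these few. Any claim that something is new, unique, unknown or untested is made for them only; others in the source may bear on it.

Compound 1 `FC(F)(F)c1ccc(Nc2nccc(-c3ccnc4ccccc34)n2)cc1` and compound 2 `Cc1ccc(Nc2nccc(-c3c(C)nc4ccccn34)n2)cc1` were both tested in a functional assay on SK-LU-1 cells (Homo sapiens) for cytotoxicity, read by sulforhodamine B assay, with a stated time of 48 h, tested at 50 uM; a higher number here means more inhibition at the concentration tested (going by the name of the read-out), a lower number less inhibition. In this assay compound 1 gives 100%, and compound 2 gives 100%, so compound 2 stands level with compound 1 at the digits shown, the two within the usual scatter. Compound 3 `Cc1nc2ccccn2c1-c1ccnc(Nc2ccc(C=O)s2)n1` carries the change (5-formylthiophen-2-yl in place of 4-methylphenyl on a nitrogen on an aromatic ring). Going by the values given here, no measured pair shows this kind of change, so nothing is known of its effect. The read-out of compound 2 leaves no room to rise. The step implied by the estimate, a number 12 percentage points lower from compound 2 to compound 3 (beyond the scatter), is expected to be none beyond the scatter or a modest fall. Compound 3 is estimated at 88%, with a range of 55% to 100%.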

Compound 3, a percentage reported as inhibition, at one concentration (the size of the read-out at that concentration, not a potency): 100%
Compound 3: the middle estimate sits 12 percentage points below what was measured; low and high end bracket the measured number.
By their numbers in this assay, from the lowest: compounds 1, 2 and 3 (each within the scatter of the next).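

In this assay, going by these compounds alone, 5-formylthiophen-2-yl in place of 4-methylphenyl on a nitrogen on an aromatic ring gives no change at the digits printed from compound 2 to compound 3 (within the scatter), the first reading of this kind of change. The position therefore accepts a five-membered aromatic ring carrying a formyl group with the reading held level, but compound 3 at 100% sits at the top of the scale at one concentration, so any difference in potency stays hidden. No evidence at hand accounts for this result.

Still open, on these data alone, is whether an amine or a carboxylic acid in place of the formyl group would hold the reading. Also open, as far as these compounds go, is whether compound 2 and compound 3 would separate at lower concentrations.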